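Trifluoromethyl on the Carbonyl Carbon: Estimating Compound 4

The source may report more compounds than this note shows. Statements on the series, on what has been measured and on what is new or still open speak of the compounds shown alone.

Of the compounds shown here, three built on a shared core have been measured in a functional assay on isolated protein for inhibition of Glucose-dependent insulinotropic receptor (Homo sapiens), read by HTRF and cAMP accumulation; a higher number here means that more compound is needed for the effect, a lower number that less compound is needed. Compound 1 `Cc1nc(S(C)(=O)=O)ccc1Oc1ncnc(OC2CCN(C(=O)OC(C)C)CC2)c1F` gives 21 nM. Compound 2 `Cc1nc(S(C)(=O)=O)ccc1Oc1ncnc(OC2CCN(C(=O)OC(C)F)CC2)c1F` gives 65.5 nM, and compound 3 `Cc1nc(S(C)(=O)=O)ccc1Oc1ncnc(OC2CCN(C(=O)O[C@@H](C)C(F)(F)F)CC2)c1F` gives 9.86 nM. Compound 3 holds the lowest number of the three: a 2.1-fold lower number from compound 1 to compound 3 (0.33 log units; beyond the scatter), and a 6.6-fold lower number from compound 2 to compound 3 (0.82 log units; beyond the scatter). The third step is a 3.1-fold higher number from compound 1 to compound 2 (0.49 log units; beyond the scatter).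

Compound 4 `Cc1nc(S(C)(=O)=O)ccc1Oc1ncnc(OC2CCN(C(=O)C(F)(F)F)CC2)c1F` differs from compound 3 in a single place: trifluoromethyl in place of 1-(trifluoromethyl)ethoxy on a carbonyl carbon. Every measured step swaps one group for another on an oxygen next to a carbonyl group, while the oxygen itself stays; here the oxygen leaves together with its group, and a trifluoromethyl sits directly on the carbonyl carbon. Within the data shown here, no measured step therefore bears on this change directly. The measured steps were all modest in size, and the variation at this position moved the numbers in both directions. A modest rise beyond the scatter is expected for compound 4, a 6.1-fold higher number from compound 3 to compound 4 (0.78 log units; beyond the scatter), with wide uncertainty. Compound 4 is estimated at 60 nM, with a range from 15 nM to 250 nM.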

Compound 4, half-maximal effective concentration: 151 nM
Beside the measured number, compound 4's estimate is 2.5-fold (0.40 log units) below it; low and high end bracket the measured number.
By their numbers in this assay, from the lowest: compound 3; then compound 1; then compound 2; then compound 4.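

In this assay, taking the oxygen away along with its group produced the largest step seen at this position, a 15-fold higher number from compound 3 to compound 4 (1.19 log units; beyond the scatter). The rise does not depend on which oxygen-bearing compound is the reference, with a 7.2-fold higher number from compound 1 to compound 4 (0.86 log units; beyond the scatter) and a 2.3-fold higher number from compound 2 to compound 4 (0.36 log units; beyond the scatter), so all three compounds that keep the oxygen on the carbonyl carbon have lower numbers than compound 4. Nothing among the available data accounts for this rise.

The compounds shown leave open how much of the rise belongs to the loss of the oxygen and how much to the trifluoromethyl, as compound 4 changes both at once. They also do not show how a methyl group or an amine on the carbonyl carbon would compare with trifluoromethyl there.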